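Swapping fluoro for nitro on the aryl ring

The source may report more compounds than this note shows. Statements on the series, on what has been measured and on what is new or still open speak of the compounds shown alone.

Of the compounds shown here, three sharing one core have been measured in a functional assay on LNCaP cells (Homo sapiens) for cytotoxicity, read by MTT assay, with a stated time of 72 h; on this read-out lower numbers stand for stronger inhibition and higher numbers for weaker inhibition. Compound 1 `CC1=C(/C=C/C(=O)/C=C/c2ccccc2)C(C)(C)CCC1O` gives 5800 nM. Compound 2 `CC1=C(/C=C/C(=O)/C=C/c2ccc(C(F)(F)F)cc2)C(C)(C)CCC1O` gives 3000 nM in this assay, and compound 3 `CC1=C(/C=C/C(=O)/C=C/c2ccc(F)cc2)C(C)(C)CCC1O` gives 3900 nM. Compound 3 stands second highest of these three numbers, with compound 2 nearest and compound 1 furthest, and both steps, a 1.3-fold higher number from compound 2 to compound 3 (0.11 log units; within the scatter) and a 1.5-fold lower number from compound 1 to compound 3 (0.17 log units; within the scatter), lie within the scatter. Compound 4 `CC1=C(/C=C/C(=O)/C=C/c2ccc([N+](=O)[O-])cc2)C(C)(C)CCC1O` differs from compound 3 by nitro in place of fluoro on an aromatic carbon, the same aromatic carbon that was varied in a 1.5-fold lower number from compound 1 to compound 3 (0.17 log units; within the scatter) and in a 1.3-fold higher number from compound 2 to compound 3 (0.11 log units; within the scatter). Those two steps stayed within the scatter, so no step beyond the scatter is expected in this assay. Compound 4 is therefore estimated at 3500 nM, with a range from 1500 nM to 8000 nM, meaning an expected step of a 1.1-fold lower number from compound 3 to compound 4 (0.05 log units; within the scatter).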

Compound 4, half-maximal inhibitory concentration: 4200 nM
Compound 4: middle estimate off by 1.2-fold (0.08 log units), on the low side; the measured number falls inside the stated range.
By their numbers in this assay, from the lowest: compounds 2, 3, 4 and 1 (each within the scatter of the next).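

Nitro, which carries more heavy atoms and hydrogen-bond acceptors than fluoro, is tolerated on this aromatic carbon in this assay with a 1.1-fold higher number from compound 3 to compound 4 (0.03 log units; within the scatter) and a 1.4-fold higher number from compound 2 to compound 4 (0.15 log units; within the scatter) and also a 1.4-fold lower number from compound 1 to compound 4 (0.14 log units; within the scatter) as its steps. Hydrogen, fluoro, trifluoromethyl and nitro at this position therefore cannot be told apart on this read-out. No measurement at hand bears on why the numbers stay so close.

Going by these compounds, whether an amine or a carboxylic acid on this carbon would move the number beyond the scatter remains open. So does whether these same groups would give such close numbers on another carbon of the ring.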